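Compound 4: iodo in place of furan-2-yl

A few compounds are considered here, and "the series" means these few. Any claim that something is new, unique, unknown or untested is made for them only; others in the source may bear on it.

Measured values in an ADME assay on BJ cells (Homo sapiens), read by MTT assay, with a stated time of 72 h (on this read-out higher numbers stand for weaker inhibition and lower numbers for stronger inhibition), follow
- Compound 1 (`CSc1ncnc2c1c(-c1ccccc1)cn2[C@@H]1O[C@H](CO)[C@@H](O)[C@H]1O`) gives > 100000 nM as a limit
- Compound 2 (`CNc1ncnc2c1c(-c1ccco1)cn2[C@@H]1O[C@H](CO)[C@@H](O)[C@H]1O`) gives 5040 nM as a number
- Compound 3 (`Nc1nc(N)c2c(-c3ccsc3)cn([C@@H]3O[C@H](CO)[C@@H](O)[C@H]3O)c2n1`) gives > 100000 nM as a limit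

Going by the values given here, compound 2 holds the only actual number among the three (5040 nM). The other two results are limits (the limit of > 100000 nM in this assay, at which 2 of the 3 values shown sit). Compound 4 (`CNc1ncnc2c1c(I)cn2[C@@H]1O[C@H](CO)[C@@H](O)[C@H]1O`) carries iodo in place of furan-2-yl on an aromatic carbon. Among the compounds with values here, no measured pair isolates this change, so its size in this assay remains uncertain. A moderate move toward weaker inhibition is expected, as the estimated 2.4-fold higher number from compound 2 to compound 4 (0.38 log units; beyond the scatter) shows. Compound 4 is estimated at 12000 nM (expected range 1500 nM to 90000 nM).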

Compound 4, half-maximal inhibitory concentration: > 100000 nM
Compound 4: only a limit was reported (the forecaster's own chance of this, stated with the estimate: 30%); middle value at least 8.3-fold (0.92 log units) away from the limit.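

In this assay, going by these compounds alone, placing iodo in place of furan-2-yl on this aromatic carbon gives an at least 19-fold higher number from compound 2 to compound 4 (1.29 log units; beyond the scatter), the first step at this position that can be read. Once furan-2-yl leaves, the measurable value of compound 2 is no longer retained. Compound 4 gives > 100000 nM, which is a limit, so the true size of the step remains unknown: the limit of > 100000 nM in this assay, at which 3 of the 4 values shown sit.

On these data alone, it remains open whether a nitrile, an amine or a short alkyl chain on this carbon would return a measurable value, or whether that takes an aromatic ring.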